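Side-chain step from compound 2 to compound 3

This account rests on a few compounds, and the source may have more. Where it says the series, first, only, none or still open, it means among the compounds named here.

Compound 2 `O=C(C[C@H]1CC[C@H](c2ccc(C(=O)Nc3nnc(Cc4ccccc4)s3)cc2)CC1)NCC(O)CO` gives < 2000 nM in a physicochemical assay for solubility, read by HPLC, in phosphate buffer, with a stated time of 20 h, at pH 7.4 (a lower number here means a less soluble compound, a higher number a more soluble compound), which is a limit and not a number. Compound 1 `CC(C)(O)CNC(=O)C[C@H]1CC[C@H](c2ccc(C(=O)Nc3nnc(Cc4ccccc4)s3)cc2)CC1` gives < 2000 nM, also a limit. Compound 3 `COCCNC(=O)C[C@H]1CC[C@H](c2ccc(C(=O)Nc3nnc(Cc4ccccc4)s3)cc2)CC1` differs from compound 2 in one place: methoxymethyl in place of 1,2-dihydroxyethyl on a saturated chain carbon bound to an amide-type nitrogen. Going by the values given here, the one measured step bearing on this change is a step that the two limits leave unreadable from compound 1 to compound 2, so it offers no size to carry over, and the series so far shows (the limit of < 2000 nM in this assay, at which 2 of the 2 values shown sit). No direction can be read, and no shift beyond the scatter is expected. The estimated step is a step that the limit leaves unreadable from compound 2 to compound 3. For compound 3 the expected value is 1000 nM, with an estimated range of 200 nM to 3000 nM.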

Compound 3, solubility: < 2000 nM
Compound 3 was reported as a limit (the forecaster's own chance of this, stated with the estimate: 75%); the middle value is on the limit's open side.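

Compound 3, like compound 1 and compound 2, is reported only as a limit in this assay, and the steps to compound 3 from compound 1 and compound 2 cannot be read. The compounds shown leave open whether these three side chains differ at all in this read-out, and in which direction.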